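Chain Length Between Ether Oxygen and Phenyl Ring

The source may report more compounds than this note shows. Statements on the series, on what has been measured and on what is new or still open speak of the compounds shown alone.

Three compounds sharing one core differ only in the group carried by the ether chain. Compound 1 `O=C1N=C(O)S/C1=C\c1ccc(OCCC2CCCCC2)cc1Cl` gives 13 nM in an assay for inhibition of 15-hydroxyprostaglandin dehydrogenase [NAD(+)] (Homo sapiens), read by fluorescence and spectrophotometry; a higher number here means a weaker inhibitor, a lower number a stronger inhibitor. Compound 2 `O=C1N=C(O)S/C1=C\c1ccc(OCCc2ccccc2)cc1Cl` gives 178 nM in this assay, and compound 3 `O=C1N=C(O)S/C1=C\c1ccc(OCCCc2ccccc2)cc1Cl` gives 52 nM in this assay. Among the three, compound 3 holds the second highest number: the step of a 4.0-fold higher number from compound 1 to compound 3 (0.60 log units; beyond the scatter) is modest, and the step of a 3.4-fold lower number from compound 2 to compound 3 (0.53 log units; beyond the scatter) is modest in the other direction. Compound 4 `O=C1N=C(O)S/C1=C\c1ccc(OCCCCc2ccccc2)cc1Cl` has not yet been measured in this assay; it differs from compound 3 by benzyl in place of phenyl on a saturated chain carbon, three bonds along the chain from an oxygen on an aromatic ring, which simply moves the phenyl ring one chain carbon further from the oxygen.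

For the measured compounds named here, the one measured step that bears directly on this change is a 3.4-fold lower number from compound 2 to compound 3 (0.53 log units; beyond the scatter), the same lengthening made one bond nearer the oxygen, which lowered the number by a modest amount. The large step of a 14-fold higher number from compound 1 to compound 2 (1.14 log units; beyond the scatter) shows that what hangs on the chain matters, but says nothing about a further carbon. A further modest lowering is therefore expected, though a single precedent is thin ground, so compound 4 is estimated at 25 nM, between 8 nM and 80 nM, a step of a 2.1-fold lower number from compound 3 to compound 4 (0.32 log units; beyond the scatter) expected from compound 3.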

Compound 4, half-maximal inhibitory concentration: 81 nM
The estimate for compound 4 lay 3.2-fold (0.51 log units) below the measured number; the whole stated range lies below it.
By their numbers in this assay, from the lowest: compound 1; then compounds 3 and 4 (each within the scatter of the next); then compound 2.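

Lengthening the chain stops paying off at this position. In this assay, compounds 3 and 4 cannot be told apart, with a 1.6-fold higher number from compound 3 to compound 4 (0.19 log units; within the scatter), so the lowering of the number seen when the same change was made one bond nearer the oxygen does not carry on here. The longer chain of compound 4 still holds a real advantage over the shortest phenyl chain, with a 2.2-fold lower number from compound 2 to compound 4 (0.34 log units; beyond the scatter), yet it does not close the gap to the cyclohexyl compound, with a 6.2-fold higher number from compound 1 to compound 4 (0.79 log units; beyond the scatter), and no evidence is at hand to explain why the trend levels off.

The compounds shown leave open whether the flat stretch continues with a chain one carbon longer than that of compound 4, or whether the number rises again at that length. Cyclohexyl appears here on only one chain length, so it remains unknown whether cyclohexyl on the longer chains of compounds 3 and 4 would follow the phenyl series, or how an amine or a carboxylic acid at the chain end would fare.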